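Swapping 2-methoxyphenyl for 3-methoxyphenyl in compound 2

The source may report more compounds than this note shows. Statements on the series, on what has been measured and on what is new or still open speak of the compounds shown alone.

In a physicochemical assay for solubility, read by chemiluminescence, in phosphate buffer, measured as kinetic solubility, at pH 7.4 (on this read-out lower numbers stand for lower solubility and higher numbers for higher solubility), compound 1 (`Cc1cnc(Nc2ccc(C(=O)NCC3(c4nc(-c5ccccc5)cs4)CCOCC3)cc2)s1`) gives < 1000 nM, which is a limit of the assay and not a number. Among the compounds with values here, compound 2 (`COc1ccccc1-c1csc(C2(CNC(=O)c3ccc(Cn4nc(C)cc4C)cc3)CCOCC2)n1`) gives 78000 nM, the only actual number so far. Compound 3 (`COc1cccc(-c2csc(C3(CNC(=O)c4ccc(Cn5nc(C)cc5C)cc4)CCOCC3)n2)c1`) has the same atoms as compound 2, joined differently, with 3-methoxyphenyl in place of 2-methoxyphenyl on an aromatic carbon. Within the data shown here, no measured step shows what such a change does, so only a slight drop within the usual scatter is expected, an estimated 1.4-fold lower number from compound 2 to compound 3 (0.15 log units; within the scatter). In this assay, compound 3 is expected to give 55000 nM, with an estimated range of 15000 nM to 120000 nM.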

Compound 3, solubility: 72000 nM
Beside the measured number, compound 3's estimate is 1.3-fold (0.12 log units) below it, within the range that was stated.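

In this assay, within the data shown here, 3-methoxyphenyl in place of 2-methoxyphenyl gives a 1.1-fold lower number from compound 2 to compound 3 (0.03 log units; within the scatter) and is the first measured step at this position, on the five-membered aromatic ring. The two methoxyphenyl groups therefore read alike here, so this change leaves the number where it was. Nothing shown here accounts for this result. Still open, from the compounds shown here alone, is what this position does with a group of another kind, such as an amine or a carboxylic acid in place of the methoxy group on the phenyl ring.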